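This account rests on a few compounds, and the source may have more. Where it says the series, first, only, none or still open, it means among the compounds named here.

Measured compounds:
Compound 1, `COc1ccc([C@@H]2C/C(=N/OCc3cn(-c4ccccc4CO)nn3)c3cc(CC=C(C)C)c(OC)cc3O2)cc1`, gives 100% in a functional assay on PC-3 cells (Homo sapiens) for inhibition, read by sulforhodamine B assay, with a stated time of 48 h, tested at 50 uM; a lower number here means less inhibition of growth, a higher number more inhibition of growth at the concentration tested.
Compound 2, `CCCCOc1ccc([C@@H]2CC(=O)c3cc(CC=C(C)C)c(OC)cc3O2)cc1`, gives 48% in this assay.
Compound 3, `COc1cc2c(cc1CC=C(C)C)C(=O)C[C@@H](c1ccc(Oc3ccc(Br)cc3)cc1)O2`, gives 55% in this assay.

Compound 1 stands highest of the three, with compound 3 closest and compound 2 furthest, both gaps beyond the scatter. The unmeasured compound 4, `COc1ccc([C@@H]2C/C(=N/OCc3cn(-c4ccc(NC(C)=O)cc4)nn3)c3cc(CC=C(C)C)c(OC)cc3O2)cc1`, differs from compound 1 in one place: 4-acetamidophenyl in place of 2-(hydroxymethyl)phenyl on an aromatic nitrogen. Going by the values given here, the only measured step, a number 7 percentage points higher from compound 2 to compound 3 (within the scatter), changes a group on a ring oxygen in the ketone series and so does not bear on the triazole substituent altered here. The change therefore rests on compound 1 alone. Compound 4 is expected to stay near the top of this set, at 90% (range 70% to 100%), an estimated step of a number 10 percentage points lower from compound 1 to compound 4 (within the scatter), within the scatter.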

Compound 4, percent growth inhibition at one concentration: 2%
Beside the measured number, compound 4's estimate is 88 percentage points above it; the measured number lies below the stated range.
By their numbers in this assay, from the lowest: compound 4; then compounds 2 and 3 (each within the scatter of the next); then compound 1.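

Going by these compounds alone, replacing 2-(hydroxymethyl)phenyl with 4-acetamidophenyl on the aromatic nitrogen gives a number 98 percentage points lower from compound 1 to compound 4 (beyond the scatter) in this assay, so the result depends strongly on the group at this position, which no earlier step touched. The two groups have the same counts of hydrogen-bond donors and acceptors, and each has one six-membered aromatic ring, so those counts do not separate them. Nothing available accounts for the step. The compounds shown cannot tell whether the loss of hydroxymethyl or the arrival of acetamido matters more. An unsubstituted phenyl or an aminophenyl at this position would help separate the two.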